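The source may hold more compounds than are shown below. What is called first, only, known or untested is meant among the compounds shown, and "the series" means these compounds.

Three compounds of this series have numbers in an assay on CHO cells for displacement of a labelled ligand from 5-hydroxytryptamine receptor 1B (Homo sapiens); a lower number here means a stronger inhibitor, a higher number a weaker inhibitor. Compound 1 `CN(CC1CCN(CCCc2c[nH]c3ccc(-n4cnnc4)cc23)CC1)C(=O)Nc1ccccc1` gives 6.2 nM, compound 2 `CC(=O)Nc1ccc([C@H](C)NCC2CCN(CCCc3c[nH]c4ccc(-n5cnnc5)cc34)CC2)cc1` gives 9.3 nM, and compound 3 `c1ccc(NCC2CCN(CCCc3c[nH]c4ccc(-n5cnnc5)cc34)CC2)nc1` gives 3.3 nM. Compound 3 holds the lowest of the three numbers; its nearest neighbour is compound 1, with a 1.9-fold lower number from compound 1 to compound 3 (0.27 log units; within the scatter), and its furthest is compound 2, with a 2.8-fold lower number from compound 2 to compound 3 (0.45 log units; beyond the scatter).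

Compound 4 `CC(=O)Nc1ccc(CNCC2CCN(CCCc3c[nH]c4ccc(-n5cnnc5)cc34)CC2)cc1` awaits measurement. It differs from compound 3 in one place: 4-acetamidobenzyl in place of pyridin-2-yl on an amine nitrogen. Among the compounds with values here, of the two measured steps, the one ending in compound 3 from compound 2 bears most directly on this change: the group that leaves there, 1-(4-acetamidophenyl)ethyl, shares the acetamidophenyl part with the entering 4-acetamidobenzyl, and that step was a 2.8-fold lower number from compound 2 to compound 3 (0.45 log units; beyond the scatter), modest but beyond the scatter. The other step, a 1.9-fold lower number from compound 1 to compound 3 (0.27 log units; within the scatter), concerns a different group and lies within the scatter, so it adds little. The move from compound 3 to compound 4 reverses the main part of the step from compound 2, so a modest increase in number is expected, about a 2.4-fold higher number from compound 3 to compound 4 (0.38 log units; beyond the scatter). Compound 4 is therefore expected to give roughly 8 nM in this assay, within a range from 3.5 nM to 20 nM.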

Compound 4, half-maximal inhibitory concentration: 8.9 nM
The estimate for compound 4 lay 1.1-fold (0.05 log units) below the measured number, within the range that was stated.
By their numbers in this assay, from the lowest: compounds 3, 1, 4 and 2 (each within the scatter of the next, the first and the last beyond it).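

In this assay, 4-acetamidobenzyl in place of pyridin-2-yl on the amine nitrogen gives a 2.7-fold higher number from compound 3 to compound 4 (0.43 log units; beyond the scatter), so this change is now measured directly, without the methyl that compound 2 carries on the saturated chain carbon. Taking that methyl away gives a 1.0-fold lower number from compound 2 to compound 4 (0.02 log units; within the scatter), which lies within the scatter, so the difference already seen with compound 2 remains when the methyl is absent, and the methyl has no readable effect in this pair. The step of a 1.4-fold higher number from compound 1 to compound 4 (0.16 log units; within the scatter) also lies within the scatter, so (4-acetamidobenzyl)amino and methyl(phenylcarbamoyl)amino cannot be told apart on this chain carbon in this assay.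

The compounds shown do not separate the contribution of the ring nitrogen of pyridin-2-yl from that of the acetamido group, and a plain benzyl or phenyl on the same amine nitrogen, or an amine or carboxylic acid in place of the acetamido group, would address that question. No measurement shown gives a reason for the size of these steps.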